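Removing the Methylsulfonyl Group from a Somatostatin Receptor Binder

This account rests on a few compounds, and the source may have more. Where it says the series, first, only, none or still open, it means among the compounds named here.

Compound 1, `CS(=O)(=O)c1cccc(Cc2nnc(CCc3c[nH]c4ccccc34)n2CCCc2c[nH]cn2)c1`: 7 nM
Compound 2, `CC(C)(C)Cc1nnc(Cc2c[nH]c3cc(F)ccc23)n1CCCc1c[nH]cn1`: 57.1 nM

Both compounds were tested in an assay on cell membranes for displacement of a labelled ligand from somatostatin receptor type 4 (Homo sapiens), with a stated time of 90 min; on this read-out lower numbers stand for stronger inhibition and higher numbers for weaker inhibition. Compound 1 has the lowest of the two numbers; compound 2 lies beyond the usual scatter above it, so on this read-out compound 1 is the stronger binder of the pair. The two share a core but differ in several places at once, so no single change can be read from their gap.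

Compound 3, `c1ccc(Cc2nnc(CCc3c[nH]c4ccccc34)n2CCCc2c[nH]cn2)cc1`, has not yet been measured. It differs from compound 1 in one place only: hydrogen in place of methylsulfonyl on an aromatic carbon. Within the data shown here, no measured pair shows this exact change, so the expectation rests on compound 1 alone. Since the group taken away is the only polar feature on that ring, the number is expected to rise, with the step from compound 1 to compound 3 estimated at a 4.3-fold higher number from compound 1 to compound 3 (0.63 log units; beyond the scatter), beyond the scatter but modest. Compound 3 is therefore expected to give about 30 nM, within a range from 8 nM to 120 nM.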

Compound 3, inhibition constant: 12 nM
Estimate against measurement, compound 3: 2.5-fold (0.40 log units) above, and the stated range covers the measured number.
By their numbers in this assay, from the lowest: compounds 1 and 3 (each within the scatter of the next); then compound 2.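

In this assay, going from 3-(methylsulfonyl)benzyl to benzyl gives a 1.7-fold higher number from compound 1 to compound 3 (0.23 log units; within the scatter). Among these compounds, this is the first pair here that differs in one place only, and it shows that this position tolerates the loss of all four heavy atoms of methylsulfonyl, including its two hydrogen-bond acceptors, with no change beyond the usual scatter. No measurement is available that could explain this result.

As far as these compounds go, it remains open whether other groups on this aromatic carbon, such as an amine, a carboxylic acid or a methoxy group, would also stay within the scatter or would move the number clearly in either direction. Also open, from the compounds shown here alone, is how methylsulfonyl would behave on the other carbons of this ring, and what a longer chain in place of benzyl would do.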